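The compounds below may be only part of what the source reports. "The series", "measured", "known", "first", "only" and "open" are said of these compounds alone.

Measured in a functional assay on A549 cells (Homo sapiens) for inhibition, read by CCK-8 assay, with a stated time of 72 h, tested at 2 uM; on this read-out higher numbers stand for more inhibition of growth at the one concentration tested and lower numbers for less inhibition of growth:
- compound 1 `Nc1ccccc1NC(=O)/C=C/c1ccc(CSc2cccc(F)c2)cc1`: 50.7%
- compound 2 `CCc1ccc(SCc2ccc(/C=C/C(=O)Nc3ccccc3N)cc2)cc1`: 60.7%
- compound 3 `CCc1ccc(SCc2ccc(C(=O)Nc3ccccc3N)cc2)cc1`: 53.6%

The three values are not separated: compound 3, at 53.6%, lies within the scatter of both compound 1 and compound 2.

The next compound, compound 4 `Nc1ccccc1NC(=O)c1ccc(CSc2ccc(Cl)cc2)cc1`, differs from compound 3 by one change: chloro in place of ethyl on an aromatic carbon. The change sits para to a large group and turns 4-ethylphenyl into 4-chlorophenyl.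

Going by the values given here, only one measured step touches the group on the sulfur: a number 10 percentage points higher from compound 1 to compound 2 (within the scatter). It lies within the scatter, and it was taken on a core that differs from that of compound 3. Among the compounds with values here, no measured compound carries 4-chlorophenyl, so the data give no direction for this change. In this assay, no step beyond the scatter is therefore expected.

The expected step is a number 1.6 percentage points lower from compound 3 to compound 4 (within the scatter).

For compound 4 the estimated value is 52%, with an expected range from 38% to 66%.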

Compound 4, percent growth inhibition at one concentration: 47.3%
Compound 4: middle estimate off by 4.7 percentage points, on the high side; the range from low to high includes it.
By their numbers in this assay, from the lowest: compounds 4, 1, 3 and 2 (each within the scatter of the next, the first and the last beyond it).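

In this assay, going by these compounds alone, the exchange of ethyl for chloro gives a number 6.3 percentage points lower from compound 3 to compound 4 (within the scatter) and is the first measured step that keeps the core fixed and changes only the group para to a large group. Within the data shown here, on this core, 4-chlorophenyl and 4-ethylphenyl therefore cannot be told apart, whereas the only earlier step on the group on the sulfur came from another core and also moved the substituent to a different place on the ring. Nothing available explains the size of this step.

The compounds shown leave open whether an amine, a carboxylic acid or a longer chain in this place would give a step beyond the scatter. They also leave open whether 4-chlorophenyl would behave the same way on the core of compound 2 .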